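A few compounds are considered here, and "the series" means these few. Any claim that something is new, unique, unknown or untested is made for them only; others in the source may bear on it.

In a functional assay on MCF7 cells (Homo sapiens) for antiproliferative activity, read by MTT assay, with a stated time of 72 h (a higher number here means a weaker inhibitor, a lower number a stronger inhibitor), compound 3 (`COc1cc(-n2ncnc2-c2ccc(C)cc2)cc(OC)c1OC`) gives 540 nM, the lowest of the two numbers obtained so far. Compound 2 (`COc1ccc(-n2ncnc2-c2cc(OC)c(OC)c(OC)c2)cc1`) gives 7400 nM, a weaker result separated from compound 3 by a gap well beyond the scatter. Compound 1 (`COc1cc(-n2ncnc2-c2cccc([N+](=O)[O-])c2)cc(OC)c1OC`) reaches the limit of this assay, > 10000 nM, which is a limit of the measurement rather than a number (the limit of > 10000 nM in this assay, at which 1 of the 3 values shown sits). Compound 4 (`COc1cc(-n2ncnc2-c2ccc(Cl)cc2)cc(OC)c1OC`) has not yet been measured; it differs from compound 3 in one place: chloro in place of methyl on an aromatic carbon. No measured pair among these compounds shows a step of this kind, so the change is expected to move the number little, if at all beyond the scatter. Compound 4 is estimated at 400 nM, within 130 nM to 1200 nM, an expected step of a 1.4-fold lower number from compound 3 to compound 4 (0.13 log units; within the scatter).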

Compound 4, half-maximal inhibitory concentration: > 10000 nM
Compound 4: only a limit was reported (the forecaster's own chance of this, stated with the estimate: 3%); middle value at least 25-fold (1.39 log units) away from the limit.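

On this aromatic carbon, para to a large group, swapping one heavy atom for another is far from neutral: in this assay, chloro in place of methyl gives an at least 18-fold higher number from compound 3 to compound 4 (1.26 log units; beyond the scatter). Among these compounds, this is the first single-place step, and it shows that the activity of compound 3 depends strongly on what occupies this carbon. Compound 4 gives a limit and not a number: the limit of > 10000 nM in this assay, at which 2 of the 4 values shown sit.

On these data alone, whether a fluoro, an ethyl or an amine on this carbon would keep the activity of compound 3 remains open. So does the true size of this step.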